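The compounds below may be only part of what the source reports. "The series", "measured", "known", "first", "only" and "open" are said of these compounds alone.

Measured so far:
compound 1, `C[C@H](NC(=O)Nc1ccccc1F)c1ccccc1`, 98%
compound 2, `C[C@H](NC(=O)Nc1cccc(F)c1)c1ccccc1`, 97%
compound 3, `C[C@@H](NC(=O)Nc1cc(F)ccc1F)c1ccccc1`, 100%

In an ADME assay on the whole organism with Oryza sativa as the target, tested at 0.1 uM (a lower number here means a stronger effect, a higher number a weaker effect of the compound at the concentration tested), compound 1 gives 98%, compound 2 gives 97% and compound 3 gives 100%. Compound 3 stands at the top of these three numbers, but the picture is flat: its nearest neighbour is compound 1, which lies within the usual scatter of repeated measurements, and even its furthest neighbour, compound 2, lies within that scatter too. No pair among these three is separated by more than the scatter, so the three readings show the same outcome at this concentration, and no ordering among them can be claimed.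

The next compound is compound 4, `C[C@H](NC(=O)Nc1cc(F)ccc1F)c1ccccc1`. Compared with compound 3 it differs as follows: the two compounds have the same atoms and bonds and differ only in configuration as drawn: 1 of 1 stereo elements differ; a stereocentre at a saturated chain carbon is drawn R in compound 3 and S in compound 4. Nothing is removed and nothing is added; only the configuration at that saturated chain carbon is drawn the other way round.

Among the compounds with values here, no measured pair differing in one place is available, so no measured step can guide an expectation here. Given that compound 1, compound 2 and compound 3 all sit within the scatter of one another in this assay, compound 4 is expected to stay in the same region, with a step of a number 2 percentage points lower from compound 3 to compound 4 (within the scatter) that amounts to nothing beyond the scatter. Compound 4 is therefore estimated at 98%, in a range from 90% to 100%.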

Compound 4, a percentage reported as activity, at one concentration (the size of the read-out at that concentration, not a potency): 100%
Compound 4: the middle estimate sits 2 percentage points below what was measured; the measured number falls inside the stated range.
By their numbers in this assay, from the lowest: compounds 2, 1, 3 and 4 (each within the scatter of the next).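

In this assay, within the data shown here, the pair of compound 3 and compound 4 gives the first direct reading of the configuration at the saturated chain carbon, and drawing that stereocentre the other way round gives no change at the digits printed from compound 3 to compound 4 (within the scatter); this comparison isolates a single change: the fact that compounds 3 and 4 differ only in the configuration as drawn. Among these compounds, the same compound 4 also gives the first readings of fluoro in place of hydrogen on an aromatic carbon, with a number 3 percentage points higher from compound 2 to compound 4 (within the scatter) and a number 2 percentage points higher from compound 1 to compound 4 (within the scatter). All three steps stay within the scatter, so at the concentration tested in this assay, neither the configuration nor the added fluoro shows an effect in these compounds.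

Because every reading in this small set lies at the same flat level, the compounds shown leave open whether any change to the shared core can lower the number in this assay at all. Whether a chloro group, an amine, a carboxylic acid or a longer chain on that core would give a step beyond the scatter, and whether the configuration would then begin to matter, remains unanswered here.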